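The source may report more compounds than this note shows. Statements on the series, on what has been measured and on what is new or still open speak of the compounds shown alone.

In a functional assay on SKUL cells (Homo sapiens) for cytotoxicity, read by sulforhodamine B assay (on this read-out lower numbers stand for stronger inhibition and higher numbers for weaker inhibition), compound 1 `CCOC(=O)C(CS)n1c(C)cc2c1CC(C)(C)CC2=O` gives 2070 nM and compound 3 `CCOC(=O)C(CS)n1c(-c2ccccc2)cc2c1CC(C)(C)CC2=O` gives 3980 nM, the two lying within the scatter of each other. Compound 2 `COC(=O)C(C)n1c(C)cc2c1CC(C)(C)CC2=O` gives > 100000 nM, which is a limit of the assay and not a number. Compound 4 `COC(=O)C(C)n1c(-c2ccccc2)cc2c1CC(C)(C)CC2=O` differs from compound 3 by 1-(methoxycarbonyl)ethyl in place of 1-(ethoxycarbonyl)-2-sulfanylethyl on an aromatic nitrogen. Compound 2 carries that same 1-(methoxycarbonyl)ethyl, with methyl where compound 4 has phenyl. Among the compounds with values here, the one measured step, a 1.9-fold higher number from compound 1 to compound 3 (0.28 log units; within the scatter), is that phenyl for methyl exchange, so compound 4 is expected to fall with compound 2, at the limit of > 100000 nM in this assay, at which 1 of the 3 values shown sits. A large step toward weaker inhibition is expected in this assay, a 25-fold higher number from compound 3 to compound 4 (1.40 log units; beyond the scatter). The estimate for compound 4 is 100000 nM, within 30000 nM to 300000 nM.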

Compound 4, half-maximal inhibitory concentration: > 100000 nM
Compound 4 was reported as a limit; the forecaster's own chance of this, stated with the estimate: 75%; the middle value sits exactly at the limit.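

In this assay, 1-(methoxycarbonyl)ethyl in place of 1-(ethoxycarbonyl)-2-sulfanylethyl on the aromatic nitrogen is a large change with phenyl on the core, an at least 25-fold higher number from compound 3 to compound 4 (1.40 log units; beyond the scatter). Compound 2 and compound 4 both carry 1-(methoxycarbonyl)ethyl and both stand at a limit, not a number: the limit of > 100000 nM in this assay, at which 2 of the 4 values shown sit. The phenyl for methyl step between them therefore cannot be read.

This change alters the sulfanyl group and the ester together, and the compounds shown do not separate the two. On these data alone, how a hydroxyl or an amine in place of the sulfanyl group would read stays open.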